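Swapping an Open Chain for Two Rings on a Shared Core

The source may hold more compounds than are shown below. What is called first, only, known or untested is meant among the compounds shown, and "the series" means these compounds.

Compound 1, `Cc1nc(N2CCC(NS(=O)(=O)N(C)C)CC2)nc2ccc(NC(=O)/C=C/c3ccc(OC(F)(F)F)cc3)cc12`, gives 105 nM in an assay on CHO-K1 cells for displacement of a labelled ligand from melanin-concentrating hormone receptor 1 (Homo sapiens), read by scintillation proximity assay, with a stated time of 2 h; a higher number here means a weaker inhibitor, a lower number a stronger inhibitor.
Compound 2, `Cc1nc(N2CCC(O)(C3CC3)CC2)nc2ccc(NC(=O)/C=C/c3ccc(C(F)(F)F)cc3)cc12`, gives 232 nM in this assay.
Compound 3, `Cc1nc(NCCCNS(C)(=O)=O)nc2ccc(NC(=O)/C=C/c3ccc(OC(F)(F)F)cc3)cc12`, gives 54 nM in this assay.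

Among these three compounds, compound 3 gives the lowest number. Compound 1 sits close enough that the two cannot be told apart within the usual scatter of repeated measurements, whereas compound 2 lies beyond that scatter. Compound 4, `Cc1nc(N2CCC(N3CCCC3=O)CC2)nc2ccc(NC(=O)/C=C/c3ccc(OC(F)(F)F)cc3)cc12`, has not yet been measured. It differs from compound 3 at a single point on the shared core: 4-(2-oxopyrrolidin-1-yl)piperidin-1-yl in place of (3-(methanesulfonamido)propyl)amino on an aromatic carbon. An open chain ending in a methanesulfonamide thus gives way to a piperidine ring carrying an oxopyrrolidine, and the hydrogen-bond donors of the leaving group are lost, as the count shows. Among the measured compounds shown here, no pair of measured compounds differs in exactly this way, so the size of the step must be judged from neighbours. Compound 1 also carries a piperidine ring at this position and gives 105 nM, while compound 3 with its open chain gives 54 nM. The step of a 2.2-fold higher number from compound 3 to compound 4 (0.35 log units; beyond the scatter) is therefore expected to be a modest rise in the number, at about the edge of the scatter. Compound 4 is estimated at 120 nM, within a range from 40 nM to 400 nM.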

Compound 4, half-maximal inhibitory concentration: 11 nM
Estimate against measurement, compound 4: 11-fold (1.04 log units) above; the whole stated range lies above it.
By their numbers in this assay, from the lowest: compound 4; then compounds 3 and 1 (each within the scatter of the next); then compound 2.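

In this assay, replacing the open chain with the two-ring group gives a 4.9-fold lower number from compound 3 to compound 4 (0.69 log units; beyond the scatter), even though the entering 4-(2-oxopyrrolidin-1-yl)piperidin-1-yl carries no hydrogen-bond donors while the leaving (3-(methanesulfonamido)propyl)amino carries two, so at this position on the shared core a low number does not require those donors or an open chain. The piperidine alone does not account for the result, since keeping it and placing 2-oxopyrrolidin-1-yl in place of (dimethylsulfamoyl)amino on its saturated ring carbon gives a 9.5-fold lower number from compound 1 to compound 4 (0.98 log units; beyond the scatter), which shows that the group on that carbon also has a large bearing on the number. No measurement available here explains why either change lowers the number.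

As far as these compounds go, what a plain pyrrolidine without the carbonyl, a six-membered lactam or a carboxylic acid would do on that saturated ring carbon remains open. From the compounds shown here alone, it also remains open whether 2-oxopyrrolidin-1-yl would give a similarly low number at the end of an open propyl chain, without the piperidine ring.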